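This account rests on a few compounds, and the source may have more. Where it says the series, first, only, none or still open, it means among the compounds named here.

In an ADME assay on Vero 76 cells (Chlorocebus sabaeus) for cytotoxicity, read by crystal violet staining, with a stated time of 96 h (a lower number here means that less compound is tolerated, a higher number that more compound is tolerated), the measured values are:
compound 1 `CC[C@H]1CC[C@H](c2ccc(NC(=S)Nc3cccc(C(F)(F)F)c3)cc2)CC1` gives 10000 nM
compound 2 `O=[N+]([O-])c1ccc(NC(=S)Nc2cccc(C(F)(F)F)c2)cc1` gives 10000 nM
compound 3 `FC(F)(F)c1cccc(NC(=S)Nc2ccccc2)c1` gives 39000 nM

Compound 3 has the highest of the three numbers (39000 nM). Compound 4 `Fc1ccccc1NC(=S)Nc1cccc(C(F)(F)F)c1` differs from it by fluoro in place of hydrogen on an aromatic carbon. Within the data shown here, no measured step introduces a fluoro. The nearest evidence is the replacement of other groups by hydrogen (a 3.9-fold higher number from compound 1 to compound 3 (0.59 log units; beyond the scatter); a 3.9-fold higher number from compound 2 to compound 3 (0.59 log units; beyond the scatter)), both modest, while those two groups show no separation from each other (no change at the digits printed from compound 1 to compound 2 (within the scatter)). A shift smaller than these steps is therefore expected in this assay, downward if anything and probably within the scatter (a 1.3-fold lower number from compound 3 to compound 4 (0.11 log units; within the scatter)). Compound 4 is estimated at 30000 nM (range 14000 nM to 60000 nM).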

Compound 4, half-maximal cytotoxic concentration: 64000 nM
Compound 4: the middle estimate sits 2.1-fold (0.33 log units) below what was measured, and the stated range ends below it.
By their numbers in this assay, from the lowest: compounds 1 and 2 (each within the scatter of the next); then compounds 3 and 4 (each within the scatter of the next).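

In this assay, among these compounds, fluoro on an aromatic carbon, ortho to a large group, gives the first direct reading of this change, a 1.6-fold higher number from compound 3 to compound 4 (0.22 log units; within the scatter). The step from phenyl to 2-fluorophenyl therefore cannot be separated from the scatter, so this position accepts a single fluorine with no resolved shift in tolerated concentration. No available data bear on the reason for this reading. From the compounds shown here alone, whether chloro, methoxy or an amine at this position would read the same remains open. So does whether fluoro elsewhere on this ring would behave like compound 4.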